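Replacing Furan with Bromophenol in a Chromene Chalcone

The source may hold more compounds than are shown below. What is called first, only, known or untested is meant among the compounds shown, and "the series" means these compounds.

Compound 1 `COc1ccc(/C=C/C(=O)c2ccc(OC)c3c2OC(C)(C)C=C3)cn1` gives only the limit > 10000 nM in a functional assay on HCT-116 cells (Homo sapiens) for antiproliferative activity, read by MTT assay, with a stated time of 24 h; on this read-out higher numbers stand for weaker inhibition and lower numbers for stronger inhibition.
Compound 2 `COc1ccc(C(=O)/C=C/c2ccco2)c2c1C=CC(C)(C)O2` gives only the limit > 10000 nM in this assay.

Compound 2 thus stands at the limit, the same place as compound 1 (the limit of > 10000 nM in this assay, at which 2 of the 2 values shown sit). For the measured compounds named here, the only measured step, a step that the two limits leave unreadable from compound 1 to compound 2, cannot be read, so no measured step gives a size for the change to compound 3 `COc1ccc(C(=O)/C=C/c2ccc(O)c(Br)c2)c2c1C=CC(C)(C)O2`, which is 3-bromo-4-hydroxyphenyl in place of furan-2-yl on a double-bonded chain carbon bound to a double-bonded chain carbon. No direction beyond the scatter can therefore be supported in this assay. The step from compound 2 is expected as an at least 1.6-fold lower number from compound 2 to compound 3 (0.22 log units; that floor lies within the scatter). Compound 3 is estimated at 6000 nM, with a range from 1500 nM to 20000 nM, and a limit remains likely.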

Compound 3, half-maximal inhibitory concentration: > 10000 nM
Compound 3: a limit, no number (the forecaster's own chance of this, stated with the estimate: 50%); at least 1.6-fold (0.22 log units) between middle value and limit.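

Compound 3 gives only a limit in this assay, so neither step to it, from compound 1 or from compound 2, can be read. The compounds shown leave open whether changing the group at this place alters the inhibition at all, as all three rest at one limit: the limit of > 10000 nM in this assay, at which 3 of the 3 values shown sit.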